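Vinyl in Place of the Hydroxybutynyl Chain

A few compounds are considered here, and "the series" means these few. Any claim that something is new, unique, unknown or untested is made for them only; others in the source may bear on it.

Compound 3 `CC1=C/C(=C\C#CCCO)C(=O)C(C)(O)C12CC2` carries a 4-hydroxybut-1-yn-1-yl group on the shared core. In a functional assay on A549 cells (Homo sapiens) for antiproliferative activity (a lower number here means a stronger inhibitor, a higher number a weaker inhibitor), compound 3 gives 3000 nM, the highest of the two numbers in hand. Its nearest neighbour is compound 2 `CC1=C/C(=C\Cl)C(=O)C(C)(O)C12CC2`, which in this assay gives 200 nM, and the step of a 15-fold higher number from compound 2 to compound 3 (1.18 log units; beyond the scatter) separates them. Compound 1 `CC1=C/C(=C\c2cccs2)C(=O)C(C)(O)C12CC2` reaches only a limit of this assay: compound 1 gives > 10000 nM. That value, (the limit of > 10000 nM in this assay, at which 1 of the 3 values shown sits), is a limit and not a number.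

Compound 4 `C=C/C=C1\C=C(C)C2(CC2)C(C)(O)C1=O` differs from compound 3 by vinyl in place of 4-hydroxybut-1-yn-1-yl on a double-bonded chain carbon bound to a double-bonded ring carbon. For the measured compounds named here, three measured steps bear on this place. From the thiophen-2-yl group the step of an at least 50-fold lower number from compound 1 to compound 2 (1.69 log units; beyond the scatter) was large, the step of an at least 3.3-fold lower number from compound 1 to compound 3 (0.52 log units; beyond the scatter) at least modest, and the step of a 15-fold higher number from compound 2 to compound 3 (1.18 log units; beyond the scatter) large in the opposite direction. Among compounds 1, 2 and 3, the group with fewer heavy atoms at that place went with the lower number each time, and vinyl is the smallest of the groups considered after chloro. A lowering step in this assay is therefore expected for compound 4, of a size between those two steps, as a 4.3-fold lower number from compound 3 to compound 4 (0.63 log units; beyond the scatter). Compound 4 is estimated at 700 nM, within a range from 150 nM to 3500 nM.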

Compound 4, half-maximal inhibitory concentration: 2 nM
For compound 4 the middle estimate is 350-fold (2.54 log units) above the measured one; measured number below the stated range.
By their numbers in this assay, from the lowest: compound 4; then compound 2; then compound 3. At a limit, above all of these: compound 1.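

Vinyl takes this place far beyond anything the earlier compounds reached in this assay, with a 1500-fold lower number from compound 3 to compound 4 (3.18 log units; beyond the scatter) and a 100-fold lower number from compound 2 to compound 4 (2.00 log units; beyond the scatter), so compound 4 has the lowest number of the four and the place on a double-bonded chain carbon bound to a double-bonded ring carbon proves far more sensitive than the earlier steps showed. Fewer heavy atoms at this place no longer goes with the lower number in every pair: compound 2 and compound 4 go against that pattern, since the larger vinyl group gives the lower number, and the size of the group alone therefore does not order these four compounds. The widest step, an at least 5000-fold lower number from compound 1 to compound 4 (3.69 log units; beyond the scatter), starts from compound 1, whose value is a limit and not a number, so it fixes only a bound on the change from thiophen-2-yl: the limit of > 10000 nM in this assay, at which 1 of the 4 values shown sits.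

Nothing measured here accounts for the sharp fall in the number at compound 4. On these data alone, it stays open whether ethyl, a longer alkenyl chain such as but-1-enyl, or a nitrile at this place would keep the number of compound 4 or lose it.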